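A few compounds are considered here, and "the series" means these few. Any claim that something is new, unique, unknown or untested is made for them only; others in the source may bear on it.

Measured compounds:
compound 1 `COC(=O)c1cc(N)c(Nc2ccc(C#N)cc2)cc1Oc1c(C)cc(/C=C/C#N)cc1C` — 89 h
compound 2 `Cc1cc(/C=C/C#N)cc(C)c1Oc1cc(Nc2ccc(C#N)cc2)c(N)cc1C(=O)OCCC#N` — 32 h
compound 3 `CCNC(=O)c1cc(N)c(Nc2ccc(C#N)cc2)cc1Oc1c(C)cc(/C=C/C#N)cc1C` — 91 h

In an ADME assay on a cell-free system (plasma, Homo sapiens) for metabolic stability, read by LC-MS, tested at 10 ug/mL (a lower number here means that the compound disappears faster, a higher number that the compound lasts longer), compound 2 gives the lowest of the three numbers, with a 2.8-fold lower number from compound 1 to compound 2 (0.44 log units; beyond the scatter) and a 2.8-fold higher number from compound 2 to compound 3 (0.45 log units; beyond the scatter) both beyond the scatter, while a 1.0-fold higher number from compound 1 to compound 3 (0.01 log units; within the scatter) lies within it. Compound 4 `Cc1cc(/C=C/C#N)cc(C)c1Oc1cc(Nc2ccc(C#N)cc2)c(N)cc1C(=O)N1CC1` differs from compound 2 as follows: aziridin-1-yl in place of 2-cyanoethoxy on a carbonyl carbon. Going by the values given here, two measured steps bear on this change: a 2.8-fold higher number from compound 2 to compound 3 (0.45 log units; beyond the scatter) and a 2.8-fold lower number from compound 1 to compound 2 (0.44 log units; beyond the scatter), each showing that the 2-cyanoethoxy group sits with the lower number, whether the alternative is ethylamino or methoxy. An aziridin-1-yl group on the carbonyl carbon is not among the measured variants, so the size is uncertain, but a modest rise in this assay is expected, a 2.3-fold higher number from compound 2 to compound 4 (0.37 log units; beyond the scatter). Compound 4 is therefore estimated at 75 h, with a range from 35 h to 140 h.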

Compound 4, half-life: 12 h
Compound 4: the middle estimate sits 6.3-fold (0.80 log units) above what was measured, and the stated range ends above it.
By their numbers in this assay, from the lowest: compound 4; then compound 2; then compounds 1 and 3 (each within the scatter of the next).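

In this assay, the 2-cyanoethoxy group does not mark the low end at this carbonyl carbon, since aziridin-1-yl goes lower still, with a 2.7-fold lower number from compound 2 to compound 4 (0.43 log units; beyond the scatter). A nitrogen on the carbonyl carbon does not by itself keep the number high: ethylamino and aziridin-1-yl are far apart, with a 7.6-fold lower number from compound 3 to compound 4 (0.88 log units; beyond the scatter), and the change from methoxy gives a 7.4-fold lower number from compound 1 to compound 4 (0.87 log units; beyond the scatter). Nothing available explains this drop. The compounds shown leave open whether the three-membered ring itself matters, and whether azetidin-1-yl, pyrrolidin-1-yl or dimethylamino would sit with compound 3 or with compound 4.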